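The source may report more compounds than this note shows. Statements on the series, on what has been measured and on what is new or still open speak of the compounds shown alone.

Working notes on the bis(trifluoromethyl)benzenesulfonamide series, a functional assay on MCF7 cells (Homo sapiens) for inhibition, read by MTT assay, with a stated time of 72 h; on this read-out lower numbers stand for stronger inhibition of growth and higher numbers for weaker inhibition of growth.

Within the data shown here, compound 1, `O=S(=O)(NCCCNCc1ccccc1Cl)c1cc(C(F)(F)F)cc(C(F)(F)F)c1`, gives 8800 nM in this assay and so stands at the higher, weaker end of the two numbers measured so far. Compound 2, `O=S(=O)(NCCCCNCc1ccc(Br)cc1)c1cc(C(F)(F)F)cc(C(F)(F)F)c1`, gives 1500 nM. Among the measured compounds shown here, the one measured step runs a 5.9-fold lower number from compound 1 to compound 2 (0.77 log units; beyond the scatter); it alters the chain length and the aryl substitution together, so it bears on the present question only loosely.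

Compound 3, `COc1ccc(CNCCCNS(=O)(=O)c2cc(C(F)(F)F)cc(C(F)(F)F)c2)cc1`, keeps the chain of compound 1 and changes only the aryl group: 4-methoxyphenyl in place of 2-chlorophenyl on a saturated chain carbon bound to an amine nitrogen. For the measured compounds named here, no measured pair isolates this change. Going by the values given here, the only precedent, the step from compound 1 to compound 2, shows a modest drop in number when the aryl group is altered alongside the chain, so a step of at most similar size, or none beyond the scatter, is expected here: a 1.8-fold lower number from compound 1 to compound 3 (0.25 log units; within the scatter). Compound 3 is estimated at 5000 nM, with a range of 1500 nM to 16000 nM.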

Compound 3, concentration for 50% growth inhibition: 2500 nM
Compound 3: middle estimate off by 2.0-fold (0.30 log units), on the high side, and the stated range covers the measured number.
By their numbers in this assay, from the lowest: compounds 2 and 3 (each within the scatter of the next); then compound 1.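

At the position on a saturated chain carbon bound to an amine nitrogen, the aryl group alone now proves able to shift the read-out in this assay: with the chain of compound 1 held, 4-methoxyphenyl in place of 2-chlorophenyl gives a 3.5-fold lower number from compound 1 to compound 3 (0.55 log units; beyond the scatter) and so isolates a change that the earlier pair altered together with the chain. Against the other measured compound there is a 1.7-fold higher number from compound 2 to compound 3 (0.22 log units; within the scatter), so no separate contribution from the chain and the 4-bromobenzyl group can be read from these values. No available evidence accounts for the size of the aryl step.

Still open, as far as these compounds go, is whether the loss of chlorine or the arrival of methoxy carries the step, which 4-chlorophenyl or plain phenyl on the same chain would separate. Also open, from the compounds shown here alone, is how 4-methoxyphenyl behaves on the longer chain of compound 2.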